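Compound 4: pyridin-3-yl in place of furan-3-yl

A few compounds are considered here, and "the series" means these few. Any claim that something is new, unique, unknown or untested is made for them only; others in the source may bear on it.

Compound 1 `Oc1cccc(-c2cc(-c3ccco3)cc(-c3ccccc3O)n2)c1`, compound 2 `Oc1cccc(-c2cc(-c3ccoc3)cc(-c3ccccc3O)n2)c1` and compound 3 `Oc1cccc(-c2cc(-c3ccoc3)cc(-c3cccc(O)c3)n2)c1` share one core and differ only in the groups attached to it. In a functional assay on DU-145 cells (Homo sapiens) for cytotoxicity, read by CCK-8 assay (on this read-out higher numbers stand for weaker inhibition and lower numbers for stronger inhibition), compound 1 gives 1790 nM, compound 2 gives 2790 nM and compound 3 gives 1650 nM. Compound 2 holds the highest number of the three, yet both neighbours sit within the scatter of it: a 1.6-fold higher number from compound 1 to compound 2 (0.19 log units; within the scatter), and a 1.7-fold lower number from compound 2 to compound 3 (0.23 log units; within the scatter). No ranking among the three follows from these numbers.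

Compound 4 `Oc1cccc(-c2cc(-c3cccnc3)cc(-c3ccccc3O)n2)c1` is reached from compound 2 by one change: pyridin-3-yl in place of furan-3-yl on an aromatic carbon. For the measured compounds named here, the only measured step at the same place, from furan-2-yl to furan-3-yl, stayed within the scatter, and the hydroxyphenyl swap on the other side did likewise. Going by the values given here, no measured step involves pyridin-3-yl, so the exchange of a five-membered for a six-membered ring is untested here. On this basis no movement beyond the scatter is expected in this assay. Compound 4 is therefore estimated at 2500 nM in this assay, with a range from 1100 nM to 5500 nM. The expected step, a 1.1-fold lower number from compound 2 to compound 4 (0.05 log units; within the scatter), is thus essentially flat.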

Compound 4, half-maximal inhibitory concentration: 5580 nM
Estimate against measurement, compound 4: 2.2-fold (0.35 log units) below; measured number outside the range, above it.
By their numbers in this assay, from the lowest: compounds 3, 1, 2 and 4 (each within the scatter of the next, the first and the last beyond it).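

At the carbon opposite the ring nitrogen, pyridin-3-yl brings a six-membered ring into the series, and in this assay it gives a 2.0-fold higher number from compound 2 to compound 4 (0.30 log units; within the scatter) and a 3.1-fold higher number from compound 1 to compound 4 (0.49 log units; beyond the scatter). For the compounds shown here, only the step from furan-2-yl leaves the scatter, and only modestly, so this position shows a limited sensitivity to the ring it carries that the furan exchange alone did not show. Against furan-3-yl, no difference can be claimed, and no available data account for the result.

As far as these compounds go, whether the step from furan-2-yl to pyridin-3-yl holds when 3-hydroxyphenyl replaces 2-hydroxyphenyl remains open. So does the response of this position to an aminomethyl group, a carboxylic acid or a longer alkyl chain in place of an aromatic ring.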